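Working notes: from compound 2 to compound 3

A few compounds are considered here, and "the series" means these few. Any claim that something is new, unique, unknown or untested is made for them only; others in the source may bear on it.

Measured so far:
- compound 1 `COc1ccc(OC)c(C(c2c[nH]c3ccc(Br)cc23)c2c[nH]c3ccc(Br)cc23)c1`: 10000 nM
- compound 2 `Brc1ccc(C(c2c[nH]c3ccc(Br)cc23)c2c[nH]c3ccc(Br)cc23)cc1`: 5600 nM

In a functional assay on A549 cells (Homo sapiens) for inhibition, read by MTT assay, with a stated time of 48 h (a lower number here means a stronger inhibitor, a higher number a weaker inhibitor), compound 2, at 5600 nM, cannot be separated from compound 1, at 10000 nM. Among the measured compounds shown here, the one measured step, a 1.8-fold lower number from compound 1 to compound 2 (0.25 log units; within the scatter), puts 4-bromophenyl in place of 2,5-dimethoxyphenyl at the same carbon and stays within the scatter.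

Next is compound 3 `CCCC(c1c[nH]c2ccc(Br)cc12)c1c[nH]c2ccc(Br)cc12`, with the change propyl in place of 4-bromophenyl on a saturated chain carbon bound to two aromatic carbons. For the measured compounds named here, only that one step bears on this change, and it compares two ring-bearing groups. Going by the values given here, no measured compound has an open chain at this carbon, so the evidence is thin and the range must stay wide. No shift beyond the scatter is expected in this assay. The expected step is a 1.3-fold higher number from compound 2 to compound 3 (0.10 log units; within the scatter). For compound 3 the estimated value is 7000 nM, with an expected range of 2500 nM to 20000 nM.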

Compound 3, half-maximal inhibitory concentration: 6500 nM
Beside the measured number, compound 3's estimate is 1.1-fold (0.03 log units) above it, and the stated range covers the measured number.
By their numbers in this assay, from the lowest: compounds 2, 3 and 1 (each within the scatter of the next).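

In this assay an open chain at this carbon gives a 1.2-fold higher number from compound 2 to compound 3 (0.06 log units; within the scatter) and a 1.5-fold lower number from compound 1 to compound 3 (0.19 log units; within the scatter) and so cannot be separated from either ring-bearing group. Among these three compounds, then, an aromatic ring on the saturated chain carbon bound to two aromatic carbons is not needed for a number in this range: propyl, 4-bromophenyl and 2,5-dimethoxyphenyl all read alike within the scatter. No measurement at hand accounts for this lack of separation.

All three steps at this carbon lie within the scatter, so the compounds shown do not reveal whether any group placed there can move the number beyond it. An amine, a carboxylic acid or a longer chain at this carbon remains an open case.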